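Amide aryl variation on the benzimidazolyl enone anilide series

The source may hold more compounds than are shown below. What is called first, only, known or untested is meant among the compounds shown, and "the series" means these compounds.

Measured so far in a functional assay on MCF7 cells (Homo sapiens) for antiproliferative activity, read by MTT assay, with a stated time of 48 h; on this read-out lower numbers stand for stronger inhibition and higher numbers for weaker inhibition:
compound 1 `Cc1ccccc1C(=O)Nc1cccc(/C=C/C(=O)c2nc3ccccc3[nH]2)c1`: 5870 nM
compound 2 `COc1ccc(C(=O)Nc2cccc(/C=C/C(=O)c3nc4ccccc4[nH]3)c2)cc1`: 20100 nM

Going by the values given here, compound 2 gives the highest number of the two; its nearest neighbour is compound 1, and the only measured step, a 3.4-fold higher number from compound 1 to compound 2 (0.53 log units; beyond the scatter), lies beyond the scatter. Compound 3 `O=C(Nc1cccc(/C=C/C(=O)c2nc3ccccc3[nH]2)c1)c1cc(Cl)cc(Cl)c1` is the next member, differing from compound 2 by 3,5-dichlorophenyl in place of 4-methoxyphenyl on a carbonyl carbon.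

Among the compounds with values here, no measured step covers this exact exchange; the step from compound 1 to compound 2 is the only one on the same carbonyl carbon and shows that a swap of the aryl group there moves the read-out by a modest amount. A change of similar size, in either direction, is the most that can be expected in this assay , with the chance of no movement beyond the scatter also real. On that basis compound 3 is estimated at 9000 nM (range 2500 nM to 30000 nM), corresponding to an expected step of a 2.2-fold lower number from compound 2 to compound 3 (0.35 log units; beyond the scatter).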

Compound 3, half-maximal inhibitory concentration: > 100000 nM
Compound 3: no number, only a limit (the forecaster's own chance of this, stated with the estimate: 10%); middle value at least 11-fold (1.04 log units) from the limit.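

In this assay compound 3 gives > 100000 nM, which is a limit of the assay and not a number: the limit of > 100000 nM in this assay, at which 1 of the 3 values shown sits.

The aryl group on the carbonyl carbon whose other neighbour is the amide-type nitrogen can move the read-out much further than the earlier pair suggested: 3,5-dichlorophenyl in place of 4-methoxyphenyl gives an at least 4.9-fold higher number from compound 2 to compound 3 (0.69 log units; beyond the scatter), and in place of 2-methylphenyl it gives an at least 17-fold higher number from compound 1 to compound 3 (1.23 log units; beyond the scatter). The three aryl groups now fall in one order, from lower to higher number: 2-methylphenyl, 4-methoxyphenyl, 3,5-dichlorophenyl.

These compounds differ in both the kind and the place of their substituents, and the two cannot be separated here. Still open, from the compounds shown here alone, are how unsubstituted phenyl or a phenyl carrying a single chlorine would read, and whether an amine or a carboxylic acid on the ring is tolerated at this position.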